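This account rests on a few compounds, and the source may have more. Where it says the series, first, only, none or still open, it means among the compounds named here.

In a functional assay on PC-3 cells (Homo sapiens) for antiproliferative activity, read by MTT assay, with a stated time of 72 h (a lower number here means a stronger inhibitor, a higher number a weaker inhibitor), compound 3 `O=C(N/N=C/c1ccccc1O)c1cccc(S(=O)(=O)N2CCOCC2)c1` gives 13800 nM, the lowest number among the two compounds that have a number at all. For the measured compounds named here, compound 2 `O=C(N/N=C/c1ccccn1)c1cccc(S(=O)(=O)N2CCOCC2)c1` gives 88100 nM in this assay, so the step of a 6.4-fold lower number from compound 2 to compound 3 (0.81 log units; beyond the scatter) is the one clear change among the measured compounds. Compound 1 `O=C(N/N=C/c1ccco1)c1cccc(S(=O)(=O)N2CCOCC2)c1` reaches only a limit of the assay, > 100000 nM, and the limit of > 100000 nM in this assay, at which 1 of the 3 values shown sits, marks where that sits. The step of an at least 1.1-fold lower number from compound 1 to compound 2 (0.05 log units; that floor lies within the scatter) therefore tells little, while the step of an at least 7.2-fold lower number from compound 1 to compound 3 (0.86 log units; beyond the scatter) again favours the 2-hydroxyphenyl.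

Compound 4 `CCN(CC)c1ccc(/C=N/NC(=O)c2cccc(S(=O)(=O)N3CCOCC3)c2)c(O)c1` is the next step: diethylamino in place of hydrogen on an aromatic carbon. Going by the values given here, none of the measured steps touches this position; each of them exchanged the whole ring on the carbon with a double bond to nitrogen, and the 2-hydroxyphenyl of compound 3 is kept here. Those steps show that the ring in that place can move the number by a modest amount, so a change on the same ring is expected to move it by no more than that, and in the same direction is the more likely guess given that the 2-hydroxyphenyl already gave the best number. Compound 4 is therefore estimated at 5000 nM, between 1500 nM and 30000 nM, a step of a 2.8-fold lower number from compound 3 to compound 4 (0.44 log units; beyond the scatter) expected from compound 3.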

Compound 4, half-maximal inhibitory concentration: 14000 nM
Compound 4: the middle estimate sits 2.8-fold (0.45 log units) below what was measured, and the stated range covers the measured number.
By their numbers in this assay, from the lowest: compounds 3 and 4 (each within the scatter of the next); then compound 2. At a limit, above all of these: compound 1.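

In this assay, diethylamino in place of hydrogen on the aromatic carbon meta to a hydroxy group and para to a large group gives a 1.0-fold higher number from compound 3 to compound 4 (0.01 log units; within the scatter). Each earlier step exchanged the whole ring on the carbon with a double bond to nitrogen, so this is the first change shown on the ring itself, and it shows that a group of 5 heavy atoms with no net charge can stand at this position without moving the number beyond the scatter, even though exchanging the ring could do so. Nothing shown here gives a reason why this step leaves the number where it was.

What the compounds leave open is whether this position stays as indifferent to other groups, since diethylamino is the only one shown there: a primary amine, a methoxy group or a carboxylic acid could behave differently. From the compounds shown here alone, it is also open whether diethylamino would matter on a ring without the hydroxy group, or whether a methoxy group in place of that hydroxy group would keep the number of the 2-hydroxyphenyl series.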